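Thiophenyl for Piperidinyl on the Aryl Ring of Compound 3

The source may report more compounds than this note shows. Statements on the series, on what has been measured and on what is new or still open speak of the compounds shown alone.

Measured compounds:
compound 1 `CO[C@@]12CCN(C)C[C@H]1[C@H](c1ccc(F)cc1)C(C#N)=C(N)O2`: 19400 nM
compound 2 `CO[C@@]12CCN(C)C[C@H]1[C@H](c1ccc(C)cc1)C(C#N)=C(N)O2`: 13200 nM
compound 3 `CO[C@@]12CCN(C)C[C@H]1[C@H](c1ccc(N3CCCCC3)cc1)C(C#N)=C(N)O2`: 19000 nM

In a functional assay on trachea (Cavia porcellus) (a lower number here means a stronger inhibitor, a higher number a weaker inhibitor), compound 3 gives 19000 nM and stands second highest of the three numbers. The steps to it are small: a 1.0-fold lower number from compound 1 to compound 3 (0.01 log units; within the scatter) and a 1.4-fold higher number from compound 2 to compound 3 (0.16 log units; within the scatter), both within the scatter, as is a 1.5-fold lower number from compound 1 to compound 2 (0.17 log units; within the scatter). All three measured steps exchange the group on the same aromatic carbon of the shared core, and none of them moves the number beyond the scatter.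

Compound 4 `CO[C@@]12CCN(C)C[C@H]1[C@H](c1ccc(-c3cccs3)cc1)C(C#N)=C(N)O2` continues this series with thiophen-2-yl in place of piperidin-1-yl on an aromatic carbon. The three swaps already seen at this place bear directly on it, and each left this assay unchanged within the scatter, so no step beyond the scatter is expected in either direction. Compound 4 is therefore expected to give 17000 nM, with a range from 6000 nM to 50000 nM. The expected step is a 1.1-fold lower number from compound 3 to compound 4 (0.05 log units; within the scatter), which is no more than the scatter of repeated measurements.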

Compound 4, half-maximal inhibitory concentration: 13800 nM
Estimate against measurement, compound 4: 1.2-fold (0.09 log units) above; the range from low to high includes it.
By their numbers in this assay, from the lowest: compounds 2, 4, 3 and 1 (each within the scatter of the next).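

In this assay, going by these compounds alone, the aromatic carbon now carries a five-membered aromatic ring with sulfur, a type of group not seen among the earlier compounds, and each step to compound 4 stays within the scatter (a 1.4-fold lower number from compound 3 to compound 4 (0.14 log units; within the scatter); a 1.0-fold higher number from compound 2 to compound 4 (0.02 log units; within the scatter); a 1.4-fold lower number from compound 1 to compound 4 (0.15 log units; within the scatter)). Among these four compounds, then, fluoro, methyl, piperidin-1-yl and thiophen-2-yl cannot be told apart at this place, whether the group is a single atom, a non-aromatic ring or an aromatic ring. No other measurement is available to account for this flat picture.

From the compounds shown here alone, whether any group at this carbon can move the number beyond the scatter remains open, for instance a carboxylic acid, an aminomethyl group or a longer alkyl chain. The compounds shown also say nothing about changes elsewhere on the shared core, such as replacing the nitrile with an amide.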